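A few compounds are considered here, and "the series" means these few. Any claim that something is new, unique, unknown or untested is made for them only; others in the source may bear on it.

Compound 1 `CCOCCn1c(N2CCN(C)CC2)nc2ccccc21` is the starting point. For the measured compounds named here, in a functional assay on ileum for inhibition of histamine H1 receptor (Cavia porcellus) (a higher number here means a weaker inhibitor, a lower number a stronger inhibitor), compound 1 gives 10 nM, the lowest of the three numbers measured so far. Compound 2 `CCCOCCn1c(N2CCCN(C)CC2)nc2ccccc21` gives 16 nM in this assay, and the gap between compound 2 and compound 1 lies within the scatter. Going by the values given here, compound 3 `CCCCCN1CCN(c2nc3ccccc3n2CCOCC)CC1` gives 30 nM; here the only single-place step known is a 3.0-fold higher number from compound 1 to compound 3 (0.48 log units; beyond the scatter), a change on the saturated chain carbon bound to the amine nitrogen in a ring.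

Compound 4 `CCSCCCn1c(N2CCN(C)CC2)nc2ccccc21` is not yet measured. It differs from compound 1 in one place: (ethylsulfanyl)methyl in place of ethoxy on a saturated chain carbon, two bonds along the chain from an aromatic nitrogen. Among the compounds with values here, no measured step touches this part of the molecule; the one step on record concerns the ring amine, not the chain two bonds along from the aromatic nitrogen, so it offers no direct guide. With nothing pointing either way, the expected step is small, a 1.5-fold higher number from compound 1 to compound 4 (0.18 log units; within the scatter), and may well sit within the scatter. For compound 4 the estimate in this assay is 15 nM, with a likely range from 5 nM to 50 nM.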

Compound 4, half-maximal inhibitory concentration: 530 nM
The estimate for compound 4 lay 35-fold (1.55 log units) below the measured number; measured number outside the range, above it.
By their numbers in this assay, from the lowest: compounds 1, 2 and 3 (each within the scatter of the next, the first and the last beyond it); then compound 4.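

Putting (ethylsulfanyl)methyl in place of ethoxy, on a saturated chain carbon two bonds along the chain from an aromatic nitrogen, gives a 53-fold higher number from compound 1 to compound 4 (1.72 log units; beyond the scatter) in this assay. For the compounds shown here, this shows that the chain is far from indifferent to change, and that this step is larger than the only other single-place step on record, a 3.0-fold higher number from compound 1 to compound 3 (0.48 log units; beyond the scatter), where butyl replaces hydrogen at the ring amine. No measurement here explains why this swap weakens inhibition so much.

The change also does two things at once, since sulfur replaces oxygen and the group gains carbon, so the compounds shown cannot say which of the two matters. A 3-ethoxypropyl chain or a 2-(ethylsulfanyl)ethyl chain in place of the 2-ethoxyethyl of compound 1 would separate these two effects.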